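This account rests on a few compounds, and the source may have more. Where it says the series, first, only, none or still open, it means among the compounds named here.

Measured so far in a physicochemical assay for metabolic stability, read by LC-MS, with a stated time of 38 days, tested at 10 mM; a higher number here means that more of the compound is left, a lower number that less of the compound is left:

Compound 1, `Cc1ccc(-c2cc(C(=O)Nc3nnc(-c4ccncc4)s3)ccn2)o1`, gives 34%.
Compound 2, `O=C(Nc1nnc(-c2ccncc2)s1)c1ccnc(-c2ccco2)c1`, gives 90%.
Compound 3, `Cc1ccc(-c2cc(C(=O)Nc3nnc(-c4ccncc4)s3)c3ccccc3c2)o1`, gives 25%.

Compound 1 and compound 2 share a core and differ in one place only: hydrogen in place of methyl on an aromatic carbon. For the measured compounds named here, that single change brought a number 56 percentage points higher from compound 1 to compound 2 (beyond the scatter), the one large step seen so far. Compound 3 is built on a different core; the difference between the two cores is not broken down here. In this assay compound 3 and compound 1 give numbers that lie within the usual scatter of each other, so nothing can be said about their order.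

Compound 4, `O=C(Nc1nnc(-c2ccncc2)s1)c1cc(-c2ccco2)cc2ccccc12`, has not yet been measured. It relates to compound 3 exactly as compound 2 relates to compound 1: hydrogen in place of methyl on an aromatic carbon, the same change at the same place on the same five-membered ring. Going by the values given here, the only guide is the pair already measured, and since that pair showed a number 56 percentage points higher from compound 1 to compound 2 (beyond the scatter), the expected step is a number 45 percentage points higher from compound 3 to compound 4 (beyond the scatter). This expected step is set a little more cautiously than the measured one: the core of compound 3 differs from that of compound 1, and the earlier step rests on a single pair. Compound 4 is therefore expected to give about 70%, most likely between 45% and 92%.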

Compound 4, percent of the compound remaining: 0%
Compound 4: the middle estimate sits 70 percentage points above what was measured, outside the stated range (below it).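

In this assay the change from 5-methylfuran-2-yl to furan-2-yl gave a number 25 percentage points lower from compound 3 to compound 4 (beyond the scatter) while the same change on the core of compound 1 gave a number 56 percentage points higher from compound 1 to compound 2 (beyond the scatter) and so the two steps run in opposite directions. This shows that, in these two pairs, the size and even the direction of the step did not carry from one core to the other, so a step measured on one core was a poor guide to the step on the other. It does not show which part of the cores matters or whether other cores would follow either pair, and nothing available here explains the reversal.

Only methyl and hydrogen are shown at this place on the five-membered ring, so it remains open how an ethyl group, a methoxy group or an amine there would behave on either core. On these data alone, with just two pairs, it also remains open which of the two steps is closer to the usual behaviour.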